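Swapping fluoro for chloro in compound 3

The source may hold more compounds than are shown below. What is called first, only, known or untested is meant among the compounds shown, and "the series" means these compounds.

Measured in a functional assay on A2780 cells (Homo sapiens) for antiproliferative activity, read by resazurin assay, with a stated time of 72 h; on this read-out higher numbers stand for weaker inhibition and lower numbers for stronger inhibition:
- compound 1 `CN(Cc1ccccc1Cl)C(=O)c1cc2c(Cc3ccccc3)n[nH]c2cc1O`: 1100 nM
- compound 2 `CN(Cc1ccccc1Br)C(=O)c1cc2c(Cc3ccccc3)n[nH]c2cc1O`: 1200 nM
- compound 3 `CN(Cc1cccc(F)c1)C(=O)c1cc2c(Cc3ccccc3)n[nH]c2cc1O`: 5000 nM

Compound 3 has the highest number of the three, so it is the weakest inhibitor. Compound 4 `CN(Cc1cccc(Cl)c1)C(=O)c1cc2c(Cc3ccccc3)n[nH]c2cc1O` carries chloro in place of fluoro on an aromatic carbon, meta to a large group (chloro in place of fluoro on an aromatic carbon). The closest measured swap of one halogen for another is a 1.1-fold higher number from compound 1 to compound 2 (0.04 log units; within the scatter). The larger steps, a 4.5-fold higher number from compound 1 to compound 3 (0.66 log units; beyond the scatter) and a 4.2-fold higher number from compound 2 to compound 3 (0.62 log units; beyond the scatter), exchange 2-chlorophenyl or 2-bromophenyl for 3-fluorophenyl, so they mix two changes. Only a small move toward stronger inhibition is therefore expected in this assay, an estimated 1.6-fold lower number from compound 3 to compound 4 (0.19 log units; within the scatter). For compound 4 the estimate is 3200 nM, with an expected range from 1300 nM to 7000 nM.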

Compound 4, half-maximal inhibitory concentration: 5300 nM
Compound 4: middle estimate off by 1.7-fold (0.22 log units), on the low side, and the stated range covers the measured number.
By their numbers in this assay, from the lowest: compounds 1 and 2 (each within the scatter of the next); then compounds 3 and 4 (each within the scatter of the next).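

In this assay, chloro in place of fluoro on this aromatic carbon makes no clear difference, a 1.1-fold higher number from compound 3 to compound 4 (0.03 log units; within the scatter), so these two halogens cannot be told apart here. With chloro on both sides, the step to 3-chlorophenyl from 2-chlorophenyl, a 4.8-fold higher number from compound 1 to compound 4 (0.68 log units; beyond the scatter), is beyond the scatter, as is the step from 2-bromophenyl, a 4.4-fold higher number from compound 2 to compound 4 (0.65 log units; beyond the scatter), so among these compounds the halogen's place on the ring matters more than its identity. Nothing measured here explains this difference. Still open, on these data alone, is how a methoxy group or an amine on this aromatic carbon would compare with fluoro and chloro.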